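A few compounds are considered here, and "the series" means these few. Any claim that something is new, unique, unknown or untested is made for them only; others in the source may bear on it.

Compound 1 `COCOc1cc(C2=C(c3cc(OC)c(OC)c(OC)c3)C(=O)CC2O[SiH2]C(C)(C)C)ccc1OC` gives 34 ug/mL in an ADME assay on DU-145 cells (Homo sapiens) for cytotoxicity, read by MTT assay, with a stated time of 72 h; on this read-out higher numbers stand for weaker inhibition and lower numbers for stronger inhibition. Compound 3 `COc1ccc(OC)c(C2=C(c3cc(OC)c(OC)c(OC)c3)C(=O)CC2O[SiH2]C(C)(C)C)c1` gives 100 ug/mL in this assay, the highest of the two numbers shown; the step of a 2.9-fold higher number from compound 1 to compound 3 (0.47 log units; beyond the scatter) separates them. Compound 2 `COc1cc(C2=C(c3cc(C)c(OC)c(C)c3)C(O)CC2=O)cc(OC)c1OC` reaches only a limit, > 100 ug/mL, in this assay; this is the limit of > 100 ug/mL in this assay, at which 1 of the 3 values shown sits, and not a number.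

Compound 4 `COc1cc(C2=C(c3cc(C)c(OC)c(C)c3)C(O[SiH2]C(C)(C)C)CC2=O)cc(OC)c1OC` is not yet measured. Compared with compound 3 the change is 4-methoxy-3,5-dimethylphenyl in place of 2,5-dimethoxyphenyl on a double-bonded ring carbon. For the measured compounds named here, no measured step covers this aryl exchange on a silyl-ether core; the only measured step, a 2.9-fold higher number from compound 1 to compound 3 (0.47 log units; beyond the scatter), exchanged one methoxy-bearing ring for another and moved the number modestly upward. Compound 2 carries the entering 4-methoxy-3,5-dimethylphenyl group, on a differently arranged core, and shows only a limit. Compound 4 is therefore expected to stay near the top of the shown range, with an expected step of no change at the digits printed from compound 3 to compound 4 (within the scatter), and with a fair chance of a limit rather than a number. The estimate for compound 4 in this assay is 100 ug/mL, from 50 ug/mL to 200 ug/mL.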

Compound 4, half-maximal inhibitory concentration: > 100 ug/mL
Compound 4: no number, only a limit; the forecaster's own chance of this, stated with the estimate: 50%; the middle value sits exactly at the limit.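

In this assay, the second exchange at this double-bonded ring carbon gives an at least 2.9-fold higher number from compound 1 to compound 4 (0.46 log units; beyond the scatter), and 4-methoxy-3,5-dimethylphenyl in place of 2,5-dimethoxyphenyl gives a number no lower from compound 3 to compound 4 (the limit leaves the size open). The size of that second step and the whole of the step between compound 2 and compound 4 cannot be read, so the group of 5 heavy atoms on the oxygen shows no readable effect with 4-methoxy-3,5-dimethylphenyl present. With this ring in place, no number has yet appeared, and the series now reaches the ceiling twice: the limit of > 100 ug/mL in this assay, at which 2 of the 4 values shown sit.

On these data alone, how far compound 4 lies past its limit stays open. Also open, as far as these compounds go, is whether an amine or a carboxylic acid on the ring at this position would bring a number back into the range of this assay.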